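Replacing bromo with methoxy in compound 2

The compounds below may be only part of what the source reports. "The series", "measured", "known", "first", "only" and "open" are said of these compounds alone.

Measured in a functional assay on HCT-116 cells (Homo sapiens) for inhibition, read by MTT assay, with a stated time of 48 h; on this read-out higher numbers stand for weaker inhibition and lower numbers for stronger inhibition:
Compound 1 `COc1ccc(CNc2cc(OC)c(OC)c(OC)c2)cc1[N+](=O)[O-]`: 18200 nM
Compound 2 `COc1cc(NCc2ccc(Br)cc2)cc(OC)c1OC`: > 80000 nM
Compound 3 `COc1cc(NCc2cccc(O)c2)cc(OC)c1OC`: 67700 nM

Compound 2 has no exact number, only a limit: > 80000 nM. Compound 4 `COc1ccc(CNc2cc(OC)c(OC)c(OC)c2)cc1` differs from it by one change, methoxy in place of bromo on an aromatic carbon. For the measured compounds named here, the one measured step that also removes the bromo group, an at least 1.1-fold lower number from compound 2 to compound 3 (0.07 log units; that floor lies within the scatter), stays within the scatter, although it starts from a limit and so gives only a floor. Compound 1 also carries a methoxy group, together with a nitro group, and gives 18200 nM. On this basis, a modest move towards stronger inhibition is expected in this assay, with an estimated at least 2.0-fold lower number from compound 2 to compound 4 (0.30 log units; that floor lies within the scatter). The estimate for compound 4 is 40000 nM, with an expected range of 15000 nM to 80000 nM.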

Compound 4, half-maximal inhibitory concentration: 18400 nM
Estimate against measurement, compound 4: 2.2-fold (0.34 log units) above; the range from low to high includes it.
By their numbers in this assay, from the lowest: compounds 1 and 4 (each within the scatter of the next); then compound 3. At a limit, above all of these: compound 2.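

In this assay, methoxy in place of bromo on this aromatic carbon, para to a large group, gives an at least 4.3-fold lower number from compound 2 to compound 4 (0.63 log units; beyond the scatter). Compound 2 carries only a limit and no exact number, so this step is a floor: the limit of > 80000 nM in this assay, at which 1 of the 4 values shown sits. The nitro group of compound 1 proves unnecessary at this level, as a 1.0-fold higher number from compound 1 to compound 4 (0.00 log units; within the scatter).

On these data alone, it remains open whether the gain comes from adding methoxy or from losing bromo. As far as these compounds go, it is also open whether an amine or a longer ether such as ethoxy on this carbon would serve equally well.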